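This account rests on a few compounds, and the source may have more. Where it says the series, first, only, none or still open, it means among the compounds named here.

Measured compounds:
compound 1 `COc1ccc(CSc2nnc(-c3cc([N+](=O)[O-])cc([N+](=O)[O-])c3)n2C)cc1`; in an ADME assay on HepG2 cells (Homo sapiens) for cytotoxicity, with a stated time of 48 h (a higher number here means a weaker inhibitor, a lower number a stronger inhibitor), compound 1 gives > 30000 nM, which is a limit of the assay and not a number.
compound 2 `Cn1c(SCc2ccc(Br)cc2)nnc1-c1cc([N+](=O)[O-])cc([N+](=O)[O-])c1`; in this assay compound 2 gives > 30000 nM, again only a limit.

Among the compounds with values here, compound 2 thus stands at the limit of this assay, and the single neighbouring value, that of compound 1, sits at the same limit, so a step that the two limits leave unreadable from compound 1 to compound 2 has no readable size; both values rest on (the limit of > 30000 nM in this assay, at which 2 of the 2 values shown sit).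

The step to compound 3 `Cn1c(SCc2ccc(Cl)cc2)nnc1-c1cc([N+](=O)[O-])cc([N+](=O)[O-])c1` is chloro in place of bromo on an aromatic carbon. Within the data shown here, no measured step gives a size that bears on this change; the only step, a step that the two limits leave unreadable from compound 1 to compound 2, alters the same aromatic carbon and leaves both ends at the limit. The expectation is therefore no shift beyond the scatter, with a step that the limit leaves unreadable from compound 2 to compound 3 as the estimated step. For compound 3 in this assay the estimate is 40000 nM, within 20000 nM to 100000 nM, and most likely reported again only as a limit.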

Compound 3, half-maximal inhibitory concentration: > 30000 nM
Compound 3: a limit, no number (the forecaster's own chance of this, stated with the estimate: 85%); the middle value lies beyond the limit too.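

Compound 3 gives > 30000 nM in this assay, which is a limit and not a number, so no step from compound 1 or compound 2 to compound 3 can be read: the limit of > 30000 nM in this assay, at which 3 of the 3 values shown sit.

The compounds shown leave open whether methoxy, bromo and chloro on this aromatic carbon differ at all in this assay.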